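Pyridin-4-yl for Phenyl on Two Related Cores

This account rests on a few compounds, and the source may have more. Where it says the series, first, only, none or still open, it means among the compounds named here.

Of the compounds shown here, three have been measured in a functional assay on A549 cells (Homo sapiens) for inhibition, read by sulforhodamine B assay, with a stated time of 48 h; a lower number here means a stronger inhibitor, a higher number a weaker inhibitor. Compound 1, `CO[C@@H]1CC=C2NN(c3cc4ccccc4[nH]3)C(=O)C[C@]2(c2ccccc2)O1`, gives 8670 nM in this assay. Compound 2, `COc1cc(OC)cc(N2NC3=CC[C@@H](OC)O[C@@]3(c3ccccc3)CC2=O)c1`, gives 17300 nM, and compound 3, `COc1cc(OC)cc(N2NC3=CC[C@@H](OC)O[C@@]3(c3ccncc3)CC2=O)c1`, gives 6220 nM. Compounds 1 and 2 differ in more than one place; the difference between the two cores is not broken down here, and their two values lie within the scatter of each other.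

Compounds 2 and 3 differ in one place: pyridin-4-yl in place of phenyl on a saturated ring carbon. This change brought a 2.8-fold lower number from compound 2 to compound 3 (0.44 log units; beyond the scatter), a modest step that lies beyond the scatter.

Compound 4, `CO[C@@H]1CC=C2NN(c3cc4ccccc4[nH]3)C(=O)C[C@]2(c2ccncc2)O1`, has not yet been measured in this assay. It differs from compound 1 by the same kind of change: pyridin-4-yl in place of phenyl on a saturated ring carbon. The surroundings of the place are not the same in the two pairs. In compound 2 the saturated ring carbon belongs to a six-membered non-aromatic ring with 2 nitrogen, two ring bonds from the ring nitrogen, three ring bonds from the ring nitrogen and three ring bonds from the ring atom that bears a large group. In compound 1 it belongs to a six-membered non-aromatic ring with 1 oxygen, next to the ring oxygen, next to the ring atom that bears a fused ring and two ring bonds from the ring atom that bears a methoxy group.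

For the measured compounds named here, the expectation for compound 4 rests on the single earlier example, a 2.8-fold lower number from compound 2 to compound 3 (0.44 log units; beyond the scatter). For compound 4 a step of a 2.5-fold lower number from compound 1 to compound 4 (0.39 log units; beyond the scatter) is expected in this assay. Going by the values given here, only one such pair exists. The expectation is therefore held loosely. Compound 4 is estimated at 3500 nM, with a range from 1500 nM to 9000 nM.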

Compound 4, half-maximal inhibitory concentration: 4050 nM
Beside the measured number, compound 4's estimate is 1.2-fold (0.06 log units) below it; the range from low to high includes it.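

In this assay, putting pyridin-4-yl in place of phenyl on the saturated ring carbon of the core of compound 1 brought a 2.1-fold lower number from compound 1 to compound 4 (0.33 log units; beyond the scatter), so the change lowered the number on this core as it had on the core of compound 2. The step therefore carried from one core to the other with its direction kept and no size difference that can be told apart, even though the surroundings of the saturated ring carbon differ between the two cores: the same change on two cores in this assay, a 2.8-fold lower number (0.44 log units; beyond the scatter) from compound 2 to compound 3 and a 2.1-fold lower number (0.33 log units; beyond the scatter) from compound 1 to compound 4, 1.3-fold (0.11 log units) apart, within the scatter of two such steps. This shows that the change travelled across these two pairs in this one cell assay, but two pairs do not establish a rule for further cores, and they do not show why the number falls or whether the step would persist in another kind of test.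

The compounds shown leave open whether the gain is particular to pyridin-4-yl, since they do not tell how a pyridin-3-yl, a pyrimidinyl ring or a phenyl carrying an amine would behave on the same saturated ring carbon. They also leave open whether the step would hold if the methoxy group on the neighbouring part of the core gave way to a longer chain such as butoxy.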